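Chloro groups on the benzyl of the series

A few compounds are considered here, and "the series" means these few. Any claim that something is new, unique, unknown or untested is made for them only; others in the source may bear on it.

Values so far in a functional assay on MDA-MB-231 cells (Homo sapiens) for cytotoxicity, read by MTT assay, with a stated time of 72 h (a lower number here means a stronger inhibitor, a higher number a weaker inhibitor), are given in brackets:
- compound 1 `CN(C)Cc1ccc2nc(NC(=O)N/N=C/c3cn(Cc4ccccc4Cl)c4ccccc34)sc2c1` (1180 nM)
- compound 2 `CN(C)Cc1ccc2nc(NC(=O)N/N=C/c3cn(Cc4ccccc4)c4ccccc34)sc2c1` (1340 nM)
- compound 3 `CCN(CC)Cc1ccc2nc(NC(=O)N/N=C/c3cn(Cc4ccccc4)c4ccccc34)sc2c1` (1470 nM)

Compound 2 cannot be separated from either of the other two, since both of its steps lie within the scatter. Compound 4 `CN(C)Cc1ccc2nc(NC(=O)N/N=C/c3cn(Cc4ccc(Cl)c(Cl)c4)c4ccccc34)sc2c1` is not yet measured. It carries 3,4-dichlorophenyl in place of phenyl on a saturated chain carbon bound to an aromatic nitrogen and the comparison starts from compound 2.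

The nearest evidence is a 1.1-fold higher number from compound 1 to compound 2 (0.06 log units; within the scatter) with hydrogen in place of chloro on an aromatic carbon. Read in reverse, it shows a single chloro making no difference beyond the scatter. The other step of a 1.1-fold higher number from compound 2 to compound 3 (0.04 log units; within the scatter) concerns the amine and bears little on this change. Within the data shown here, no measured compound carries the 3,4-dichlorobenzyl group, so the range is kept wide.

The expected change is a 1.3-fold lower number from compound 2 to compound 4 (0.11 log units; within the scatter) and no step beyond the scatter is anticipated. Compound 4 is estimated at 1050 nM with an expected range from 550 nM to 1900 nM in this assay here.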

Compound 4, half-maximal inhibitory concentration: 1000 nM
For compound 4 the middle estimate is 1.1-fold (0.02 log units) above the measured one, and the stated range covers the measured number.
By their numbers in this assay, from the lowest: compounds 4, 1, 2 and 3 (each within the scatter of the next).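

Benzyl to 3,4-dichlorobenzyl, on a saturated chain carbon bound to an aromatic nitrogen, gives a 1.3-fold lower number from compound 2 to compound 4 (0.13 log units; within the scatter) in this assay, so two chloro groups on the benzyl stay as close to the unsubstituted group as the single chloro of compound 1 does. Exchanging 2-chlorophenyl for 3,4-dichlorophenyl gives a 1.2-fold lower number from compound 1 to compound 4 (0.07 log units; within the scatter), so neither the number of chloro groups nor their places, as far as these compounds show them, separates the compounds at this position. No supporting measurement bears on this result.

The compounds shown leave open whether any replacement at this place moves the number beyond the scatter, for instance a pyridine ring in place of the phenyl or a carboxylic acid on it. They also leave open whether 3,4-dichlorobenzyl gives the same reading with diethylamino in place of dimethylamino.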